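From Ethylamino to Propylamino: A Small Chain Extension

This account rests on a few compounds, and the source may have more. Where it says the series, first, only, none or still open, it means among the compounds named here.

Compound 1 (`CC(=O)Nc1ccc(NC(=O)c2cc(Cl)ccc2O)c(Cl)c1`): "not determined" (no result reported)
Compound 2 (`CCNc1ccc(NC(=O)c2cc(Cl)ccc2O)c(Cl)c1`): 30200 nM

Going by the values given here, in an ADME assay on A549 cells (Homo sapiens) for cytotoxicity, read by resazurin assay, with a stated time of 48 h (on this read-out higher numbers stand for lower toxicity in this test and lower numbers for higher toxicity in this test), compound 2 supplies the only number so far, since compound 1 has no reported result. That leaves a single point of reference and no ranking.

Compound 3 (`CCCNc1ccc(NC(=O)c2cc(Cl)ccc2O)c(Cl)c1`) is not yet measured. Its structure differs from compound 2 in one place: methyl in place of hydrogen on a saturated chain carbon, two bonds along the chain from a nitrogen on an aromatic ring turns ethylamino into propylamino. No measured step among these compounds shows what such a change does, so any expectation here is loose. Given how small the change is, a small shift toward lower numbers in this assay is expected, possibly none beyond the usual scatter. The estimate below means a 1.3-fold lower number from compound 2 to compound 3 (0.10 log units; within the scatter) as the expected change. Compound 3 is estimated at 24000 nM with an expected span from 10000 nM to 55000 nM around that figure.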

Compound 3, half-maximal cytotoxic concentration: 22500 nM
For compound 3 the middle estimate is 1.1-fold (0.03 log units) above the measured one, within the range that was stated.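

Going by these compounds alone, the first measured step at this position comes out as a 1.3-fold lower number from compound 2 to compound 3 (0.13 log units; within the scatter) in this assay. Adding one methyl on a saturated chain carbon, two bonds along the chain from a nitrogen on an aromatic ring, therefore gives a result that repeated measurements alone could produce, and compound 2 and compound 3 cannot be told apart by this read-out. No measurement shown here accounts for this result.

From the compounds shown here alone, whether a longer chain, such as butylamino, would move the number beyond the usual scatter remains open. So does the effect of replacing the propylamino group with a chain carrying a hydroxyl group or a carboxylic acid in this assay, since a single step within the scatter cannot predict either change.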